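Hydrazone series: a fluorophenyl arm in place of dihydroxyphenyl

This account rests on a few compounds, and the source may have more. Where it says the series, first, only, none or still open, it means among the compounds named here.

Compound 1 `Cc1c(C(=O)N/N=C\c2ccc(O)c(O)c2O)oc2cccc(O)c12`: in a functional assay on PC-3 cells (Homo sapiens) for inhibition (on this read-out lower numbers stand for stronger inhibition and higher numbers for weaker inhibition), compound 1 gives >= 40000 nM, which is a limit of the assay and not a number.
Compound 2 `Cc1c(C(=O)N/N=C\c2cccc(O)c2O)oc2cccc(O)c12`: in this assay compound 2 gives 12200 nM.
Compound 3 `Cc1c(C(=O)N/N=C\c2cc(Cl)cc(Cl)c2O)oc2cccc(O)c12`: in this assay compound 3 gives 9590 nM.

Compound 2 holds the highest of the two plain numbers; the nearest value, that of compound 3, lies within the scatter of it, so the two cannot be ordered. Compound 1 sits at the limit (the limit of >= 40000 nM in this assay, at which 1 of the 3 values shown sits).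

Compound 4 `Cc1c(C(=O)N/N=C\c2ccc(F)cc2)oc2cccc(O)c12` is not yet measured. It differs from compound 2 in one place: 4-fluorophenyl in place of 2,3-dihydroxyphenyl on a carbon with a double bond to nitrogen.

Among the compounds with values here, only one measured step bears on this change: an at least 3.2-fold lower number from compound 1 to compound 2 (0.51 log units; beyond the scatter), where hydrogen took the place of a hydroxy group on the aromatic ring. Within the data shown here, compound 4 likewise loses hydroxy groups from the same ring, so a lower number is the natural expectation, though the fluorine it gains has no counterpart among the measured compounds, and the gap between compound 2 and compound 3 shows that changes on this ring can also stay within the scatter.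

Compound 4 is therefore estimated at 7000 nM, with a range from 2500 nM to 20000 nM. This estimate means an expected step of a 1.7-fold lower number from compound 2 to compound 4 (0.24 log units; within the scatter), modest and close to the edge of the scatter.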

Compound 4, half-maximal inhibitory concentration: >= 40000 nM
Compound 4 gave a limit, no number; the forecaster's own chance of this, stated with the estimate: 10%; middle value at least 5.7-fold (0.75 log units) from the limit.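

In this assay, 4-fluorophenyl in place of 2,3-dihydroxyphenyl on the carbon with a double bond to nitrogen gives an at least 3.2-fold higher number from compound 2 to compound 4 (0.51 log units; beyond the scatter), so this position does not accept every arm without loss. The earlier step, an at least 3.2-fold lower number from compound 1 to compound 2 (0.51 log units; beyond the scatter), came with hydrogen in place of hydroxy on the aromatic ring, whereas the present change also removes hydroxy groups and runs the opposite way, so in these compounds removing hydroxy groups from this arm does not by itself set the direction. Compound 1 and compound 4 each sit at a limit of the assay, not at a number, and no order can be set between them: the limit of >= 40000 nM in this assay, at which 2 of the 4 values shown sit.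

Compound 4 loses both hydroxy groups and gains fluorine in a single change, and the compounds shown do not separate these two parts. Going by these compounds, it remains open how an unsubstituted phenyl arm, a 4-hydroxyphenyl arm or an arm bearing an amine or a carboxylic acid would read at this position.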